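This account rests on a few compounds, and the source may have more. Where it says the series, first, only, none or still open, it means among the compounds named here.

Of the compounds shown here, two built on one shared core have been tested in an assay on isolated protein (strain Sprague-Dawley) for inhibition of Amine oxidase [flavin-containing] A (Rattus norvegicus), read by spectrophotometry, with a stated time of 5 min, tested at 10 uM; a lower number here means less inhibition, a higher number more inhibition at the concentration tested (going by the name of the read-out). Compound 1 `COc1cc(=O)oc2cc(OCc3cccc(Br)c3)ccc12` gives 27% there. Compound 2 `CC(C)Oc1cc(=O)oc2cc(OCc3cccc(Cl)c3)ccc12` gives 3% in this assay, the lower of the two numbers; compound 1 is its nearest neighbour and stands higher by a gap beyond the usual scatter. Going by the values given here, no measured pair differs in a single place, so no counted step exists between them. Compound 3 `CC(=O)COc1cc(=O)oc2cc(OCc3cccc(Cl)c3)ccc12` has not yet been measured. It differs from compound 2 in one place: 2-oxopropyl in place of isopropyl on an oxygen on an aromatic ring. Among the compounds with values here, no measured pair in this set shows what an exchange of this kind on that oxygen does, so the data give no direction for the step. The expected step is a number 7 percentage points higher from compound 2 to compound 3 (within the scatter), a change that would not rise beyond the scatter. Compound 3 is accordingly estimated at 10% in this assay, with a range from 0% to 35%.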

Compound 3, a percentage reported as inhibition, at one concentration (the size of the read-out at that concentration, not a potency): 22%
Compound 3: middle estimate off by 12 percentage points, on the low side, and the stated range covers the measured number.
By their numbers in this assay, from the lowest: compound 2; then compounds 3 and 1 (each within the scatter of the next).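

In this assay, going by these compounds alone, the exchange of isopropyl for 2-oxopropyl on an oxygen on an aromatic ring reads a number 19 percentage points higher from compound 2 to compound 3 (beyond the scatter), the first counted step at this position. It shows that the read-out responds to the group on this oxygen, at least for this one exchange on the shared core. The entering group brings one hydrogen-bond acceptor and one double bond that isopropyl lacks, but nothing measured here links the step to either feature or gives a reason for it.

Still open, on these data alone, is whether the carbonyl itself matters, which a 2-hydroxypropyl group on the same oxygen could test, and how an amine or a longer alkyl chain there would compare. Compound 1 differs from compound 2 and compound 3 in more than one place, so it cannot show what the smaller methoxy group does at this position.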